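Trading a Fluorophenyl for a Methylphenyl: Solubility Outlook

The compounds below may be only part of what the source reports. "The series", "measured", "known", "first", "only" and "open" are said of these compounds alone.

Of the compounds shown here, three sharing one core have been measured in a physicochemical assay for solubility, in phosphate buffer, at pH 7.4; on this read-out lower numbers stand for lower solubility and higher numbers for higher solubility. Compound 1 `CCOC(=O)c1c(-c2cccc(C(F)(F)F)c2)[nH]c2cc(OC)ccc2c1=O` gives 19000 nM. Compound 3 `CCOC(=O)c1c(-c2cccc([N+](=O)[O-])c2)[nH]c2cccc(OC)c2c1=O` gives 49000 nM. Compound 2 `CCOC(=O)c1c(-c2cccc(F)c2)[nH]c2cc(OC)ccc2c1=O` reaches the ceiling of this assay and gives > 100000 nM, which is a limit rather than a number. Among the compounds with values here, the only step between two compounds that differ in a single place is an at least 5.2-fold higher number from compound 1 to compound 2 (0.72 log units; beyond the scatter), and its size is known only as a bound, because compound 2 sits at the limit of > 100000 nM in this assay, at which 1 of the 3 values shown sits.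

Compound 4 `CCOC(=O)c1c(-c2ccccc2C)[nH]c2cc(OC)ccc2c1=O` has not yet been measured in this assay. It differs from compound 2 by 2-methylphenyl in place of 3-fluorophenyl on an aromatic carbon. Within the data shown here, no measured step exchanges one of these aryl groups for the other, so the step from compound 1 to compound 2 is the only one that bears on it, and it shows that the aryl group alone can move this read-out by a modest amount or more. Compound 2 stands at a limit, so the number for compound 4 is expected to fall short of that reading. This expectation rests on compound 1, which gives 19000 nM, and on compound 3, which gives 49000 nM, both with other aryl groups on the same core. Compound 4 is therefore expected to give about 40000 nM, within a range from 10000 nM to 150000 nM. The expected step is an at least 2.5-fold lower number from compound 2 to compound 4 (0.39 log units; beyond the scatter), toward a lower number in this assay, although a second limit reading cannot be ruled out.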

Compound 4, solubility: > 100000 nM
Compound 4: only a limit was reported (the forecaster's own chance of this, stated with the estimate: 25%); middle value at least 2.5-fold (0.39 log units) from the limit.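

Compound 4 gives > 100000 nM in this assay, which is a limit and not a number. Compound 2 stands at the same limit, so no step between compound 2 and compound 4 can be read, in size or in direction: the limit of > 100000 nM in this assay, at which 2 of the 4 values shown sit.

The compounds shown leave open whether 2-methylphenyl or 3-fluorophenyl gives the higher number on the shared core.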